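From a Cyclopropylmethyl Amide to an Azetidine Amide

The source may report more compounds than this note shows. Statements on the series, on what has been measured and on what is new or still open speak of the compounds shown alone.

Of the compounds shown here, three have been measured in a functional assay on the whole organism with Rattus norvegicus as the target, at a dose of 20 mg/kg by the oral route; a higher number here means more inhibition at the dose given (going by the name of the read-out), a lower number less inhibition. Compound 1 `O=C(/C=C1\CCc2cc(Cl)ccc21)NC1CC1` gives 34% in this assay, compound 3 `NC(=O)/C=C1\CCc2cc(F)cc(F)c21` gives 54%, and compound 2 `O=C(/C=C1\CCc2ccc(F)cc21)NCC1CC1` gives 0%. Compound 2 thus stands lowest of the three numbers: compound 1 lies nearest, higher by more than the scatter, and compound 3 lies furthest, higher again by more than the scatter. Within the data shown here, no two measured compounds differ in a single place, so no measured step is available.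

Compound 4 `O=C(/C=C1\CCc2ccc(F)cc21)N1CCC1` has not yet been measured. It differs from compound 2 in one place: azetidin-1-yl in place of (cyclopropylmethyl)amino on a carbonyl carbon. The group that leaves is (cyclopropylmethyl)amino and the group that enters is azetidin-1-yl, on the carbonyl carbon whose other neighbour is a double-bonded chain carbon.

Because compound 2 gave only 0% while the other two amides gave higher numbers, a modest upward step is expected. The expected step of a number 15 percentage points higher from compound 2 to compound 4 (beyond the scatter) is small and may stay within the scatter. Compound 4 is expected to give about 15%, within a range from 0% to 45%.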

Compound 4, a percentage reported as inhibition, in the whole organism at one dose (the size of the read-out at that dose, not a potency): 14%
Estimate against measurement, compound 4: 1 percentage points above, within the range that was stated.
By their numbers in this assay, from the lowest: compound 2; then compound 4; then compound 1; then compound 3.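

Among these compounds, on the carbonyl carbon of the shared core, azetidin-1-yl in place of (cyclopropylmethyl)amino gives the first step that can be read at this position in this assay: a number 14 percentage points higher from compound 2 to compound 4 (beyond the scatter). The position therefore responds to a change of amide group, even though the step is modest. The entering group carries no hydrogen-bond donor where the leaving group carries one, but nothing shown here links the step to that difference or to any other feature of the change.

Going by these compounds, it remains open whether dimethylamino, which also lacks the amide hydrogen but has no ring, would give a number like that of compound 4, or whether pyrrolidin-1-yl or morpholin-4-yl would shift it further. The compounds shown also leave open whether the same exchange would give a similar step on the cores of compound 1 and compound 3.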